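A few compounds are considered here, and "the series" means these few. Any claim that something is new, unique, unknown or untested is made for them only; others in the source may bear on it.

Measured so far in a functional assay on PANC-1 cells (Homo sapiens) for inhibition, read by MTT assay, with a stated time of 24 h, tested at 10 uM; a lower number here means less inhibition, a higher number more inhibition at the concentration tested (going by the name of the read-out):
- compound 1 `COc1ccccc1NC(=O)Oc1cc(=O)n(CCCO)c2c1CC(CC=C(C)C)C(C)(C)C2` gives 71.1%
- compound 2 `CC(C)=CCC1Cc2c(OC(=O)Nc3ccc(F)cc3)cc(=O)n(CCCO)c2CC1(C)C` gives 71.2%
- compound 3 `COc1ccccc1NC(=O)Oc1cc(=O)n(CCCO)c2c1CC(C/C=C(\C)CCC=C(C)C)C(C)(C)C2` gives 53%

Compound 4 `CC(C)=CCC/C(C)=C/CC1Cc2c(OC(=O)Nc3ccc(F)cc3)cc(=O)n(CCCO)c2CC1(C)C` is not yet measured.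

The change from compound 1 to compound 2 is 4-fluorophenyl in place of 2-methoxyphenyl on an amide-type nitrogen and gave a number 0.1 percentage points higher from compound 1 to compound 2 (within the scatter). The cores of compound 1 and compound 3 differ by 3-methylbut-2-en-1-yl in place of hydrogen on a saturated chain carbon bound to a double-bonded chain carbon, which gave a number 18.1 percentage points lower from compound 1 to compound 3 (beyond the scatter), so compound 3 stands lowest of the three. The change from compound 3 to compound 4 is 4-fluorophenyl in place of 2-methoxyphenyl on an amide-type nitrogen; the place lines read the same word for word, so this is the same change as from compound 1 to compound 2, made on the core of compound 3. Because a number 0.1 percentage points higher from compound 1 to compound 2 (within the scatter) lay within the scatter, the step from compound 3 to compound 4 is expected to be no change at the digits printed from compound 3 to compound 4 (within the scatter), also within the scatter. Compound 4 is therefore estimated at 53%, between 41% and 65%.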

Compound 4, a percentage reported as inhibition, at one concentration (the size of the read-out at that concentration, not a potency): 43.9%
The estimate for compound 4 lay 9.1 percentage points above the measured number, and the stated range covers the measured number.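

In this assay, 4-fluorophenyl in place of 2-methoxyphenyl on the amide-type nitrogen gave a number 9.1 percentage points lower from compound 3 to compound 4 (within the scatter), and this step agrees with the one on the other core: the same change on two cores in this assay, a number 0.1 percentage points higher (within the scatter) from compound 1 to compound 2 and a number 9.1 percentage points lower (within the scatter) from compound 3 to compound 4, 9.2 percentage points apart, within the scatter of two such steps

Adding 3-methylbut-2-en-1-yl to the saturated chain carbon gave a number 27.3 percentage points lower from compound 2 to compound 4 (beyond the scatter), which also agrees with its counterpart: the same change on two cores in this assay, a number 18.1 percentage points lower (beyond the scatter) from compound 1 to compound 3 and a number 27.3 percentage points lower (beyond the scatter) from compound 2 to compound 4, 9.2 percentage points apart, within the scatter of two such steps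

Both changes therefore carried between the two cores within the scatter, but two pairs at a single concentration do not show that they would carry to other cores in the series, nor do they give a potency.

The compounds shown leave open how an aryl group bearing a nitrile or a carboxylic acid would behave on the amide-type nitrogen. They also leave open whether a chain longer than that of compound 3 and compound 4 would lower the number further.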